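Replacing 3-nitrophenyl with 2,5-dimethylphenyl: expected cytotoxicity

The compounds below may be only part of what the source reports. "The series", "measured", "known", "first", "only" and "open" are said of these compounds alone.

In a functional assay on HeLa cells (Homo sapiens) for cytotoxicity, read by MTT assay, with a stated time of 48 h (on this read-out lower numbers stand for stronger inhibition and higher numbers for weaker inhibition), compound 1 (`CC1(C)CCC[C@]2(C)[C@@H](CC[C@@](C)(O)/C=C/c3ccccc3)[C@](C)(O)CC[C@@H]12`) gives 3320 nM, and compound 2 (`CC1(C)CCC[C@]2(C)[C@@H](CC[C@@](C)(O)/C=C/c3cccc([N+](=O)[O-])c3)[C@](C)(O)CC[C@@H]12`) gives 3380 nM. Among the measured compounds shown here, compound 2 therefore stands level with compound 1, the only other measured compound, with the two values within the scatter of each other.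

Compound 3 (`Cc1ccc(C)c(/C=C/[C@](C)(O)CC[C@@H]2[C@@]3(C)CCCC(C)(C)[C@@H]3CC[C@@]2(C)O)c1`) has 2,5-dimethylphenyl in place of 3-nitrophenyl on a double-bonded chain carbon bound to a double-bonded chain carbon.

For the measured compounds named here, one measured step bears on this change: a 1.0-fold higher number from compound 1 to compound 2 (0.01 log units; within the scatter), for nitro in place of hydrogen on an aromatic carbon. Going by the values given here, no measured step tests methyl groups on the aromatic ring, so this evidence is limited. No step beyond the scatter is expected in this assay. The expected step is a 1.1-fold lower number from compound 2 to compound 3 (0.05 log units; within the scatter). The estimate for compound 3 is 3000 nM, with an expected range of 1300 nM to 7000 nM.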

Compound 3, half-maximal inhibitory concentration: 3380 nM
Compound 3: the middle estimate sits 1.1-fold (0.05 log units) below what was measured, and the stated range covers the measured number.
By their numbers in this assay, from the lowest: compounds 1, 2 and 3 (each within the scatter of the next).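

In this assay the exchange of 3-nitrophenyl for 2,5-dimethylphenyl gives no change at the digits printed from compound 2 to compound 3 (within the scatter) and the exchange of phenyl for 2,5-dimethylphenyl gives a 1.0-fold higher number from compound 1 to compound 3 (0.01 log units; within the scatter) so all three aryl groups now stand level. The earlier pair tested only a nitro group, whereas compound 3 shows that at this place, on a double-bonded chain carbon bound to a double-bonded chain carbon, a group of carbon only with two methyl groups also leaves the number within the scatter of phenyl and 3-nitrophenyl. Nothing available accounts for this flat response.

From the compounds shown here alone, whether any aromatic substituent can move the number at all remains open, for example an amine or a carboxylic acid on the ring. Also open, going by these compounds, is the effect of a longer chain between the shared core and the aromatic ring.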